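Urea Replaces Thiourea on the Ring Nitrogen

The source may report more compounds than this note shows. Statements on the series, on what has been measured and on what is new or still open speak of the compounds shown alone.

Compound 1 `NC(=O)c1c(NC(=O)c2ccccc2Cl)sc2c1CCN(Cc1c(Cl)cccc1Cl)C2`: 28800 nM
Compound 2 `NC(=O)c1c(NC(=O)c2ccccc2Cl)sc2c1CCN(C(=S)Nc1ccccc1Br)C2`: 24600 nM

Both compounds were tested in a functional assay on HeLa cells (Homo sapiens) for antiproliferative activity, with a stated time of 24 h; on this read-out higher numbers stand for weaker inhibition and lower numbers for stronger inhibition. On these two numbers compound 2 holds the lower one, but the gap is only a 1.2-fold lower number from compound 1 to compound 2 (0.07 log units; within the scatter), so the two cannot be told apart.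

Compound 3 `NC(=O)c1c(NC(=O)c2ccccc2Cl)sc2c1CCN(C(=O)Nc1c(Cl)cccc1Cl)C2` has not yet been measured. It differs from compound 2 in this way: a group of 11 heavy atoms (7 carbon, 1 nitrogen, 1 oxygen, 2 chlorine; one six-membered aromatic ring of carbon only) in place of a group of 10 heavy atoms (7 carbon, 1 nitrogen, 1 sulfur, 1 bromine; one six-membered aromatic ring of carbon only), on an amine nitrogen in a ring. Among the measured compounds shown here, the only measured step that bears on this is a 1.2-fold lower number from compound 1 to compound 2 (0.07 log units; within the scatter), which swapped the group on the same amine nitrogen in a ring, including the aromatic ring's halogen pattern, and left the number within the scatter. With no other evidence, a step of similar size is expected, that is, none beyond the scatter. The expected step is a 1.0-fold higher number from compound 2 to compound 3 (0.01 log units; within the scatter). Compound 3 is therefore estimated at 25000 nM, with a range from 8000 nM to 80000 nM.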

Compound 3, half-maximal inhibitory concentration: 27200 nM
Beside the measured number, compound 3's estimate is 1.1-fold (0.04 log units) below it; the range from low to high includes it.
By their numbers in this assay, from the lowest: compounds 2, 3 and 1 (each within the scatter of the next).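

In this assay, (2,6-dichlorophenyl)carbamoyl on the amine nitrogen in a ring gives a 1.1-fold lower number from compound 1 to compound 3 (0.02 log units; within the scatter) when it replaces 2,6-dichlorobenzyl, and both groups carry the same dichlorinated aromatic ring. With that ring held constant, changing how it is linked to the nitrogen leaves the number within the scatter, which the first pair could not show since its ring also changed; the further step, a 1.1-fold higher number from compound 2 to compound 3 (0.04 log units; within the scatter), likewise stays within the scatter, so three different groups at this position cannot be told apart. No measurement on hand explains why these groups read alike.

The compounds shown leave open whether a group without an aromatic ring, such as acetyl, or an aromatic ring carrying an amine or a carboxylic acid, would shift the number at this nitrogen. In compound 2 and compound 3, sulfur and oxygen also change together with the halogens, so neither exchange can be read alone.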